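The compounds below may be only part of what the source reports. "The series", "measured", "known", "first", "only" and "open" are said of these compounds alone.

Measured in a functional assay on HL-60 cells (Homo sapiens) for antiproliferative activity, read by MTT assay; a higher number here means a weaker inhibitor, a lower number a stronger inhibitor:
- compound 1 `CC(C)C[C@@H]1O[C@H](COCc2ccccc2)[C@H](OCc2ccccc2)[C@H](OCc2ccccc2)[C@H]1O`: "not active" (no number reported)
- compound 2 `CC(C)C[C@H]1O[C@H](COCc2ccccc2)[C@H](OCc2ccccc2)[C@H](OCc2ccccc2)[C@H]1O`: "not active" (no number reported)
- compound 3 `CC(C)C[C@@H]1O[C@H](COCc2ccccc2)[C@@H](OCc2ccccc2)[C@H](OCc2ccccc2)[C@H]1O`: 8500 nM

These three structures are closely related: the fact that compounds 1 and 2 differ only in the configuration as drawn, the fact that compounds 1 and 3 differ only in the configuration as drawn and (the fact that compounds 2 and 3 differ only in the configuration as drawn). Even so, only compound 3 gives a number, at 8500 nM. In this assay, compound 1 is recorded as "not active" (no number reported), so it has no single value to serve as a starting point. Compound 2 shares that position, at "not active" (no number reported).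

The next structure is compound 4 `CCC[C@@H]1O[C@H](COCc2ccccc2)[C@H](OCc2ccccc2)[C@H](OCc2ccccc2)[C@H]1O`. It differs from compound 1 by a change in the side chain: hydrogen in place of methyl on a saturated chain carbon bound to two saturated chain carbons. Hydrogen stands in place of methyl on a saturated chain carbon bound to two saturated chain carbons, which turns isobutyl into propyl.

Among the measured compounds shown here, no measured pair shows what this change does, so any forecast rests on very little. The expectation is no clear gain in potency, since the starting point is compound 1 at "not active" (no number reported). Compound 4 may well be reported without a number too. If a number does appear, it is expected to be a weak one, in the region of compound 3 at 8500 nM.

The estimate for compound 4 is 15000 nM, with an expected range of 5000 nM to 50000 nM.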

Compound 4, half-maximal inhibitory concentration: "not active" (no number reported)
The entry for compound 4 holds no number, and the estimate cannot be compared.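

Compound 1 and compound 4 are both recorded as not active in this assay without a number, so no step can be read for the change from isobutyl to propyl, and nothing shown bears on this result. Still open, going by these compounds, is how that change would act in the configuration of compound 3, which gives 8500 nM in this assay.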